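Swapping One Nitro-Bearing Aryl Ketone for Another

This account rests on a few compounds, and the source may have more. Where it says the series, first, only, none or still open, it means among the compounds named here.

Compound 2 (`COC(=O)c1cc(-c2cccc(NC(=O)c3ccc(/C=C/C(=O)c4ccc(C)c([N+](=O)[O-])c4)cc3)c2)on1`) was examined in an ADME assay on Vero cells (Chlorocebus sabaeus) for cytotoxicity, read by MTT assay, with a stated time of 72 h; on this read-out lower numbers stand for higher toxicity in this test and higher numbers for lower toxicity in this test. In this assay compound 2 gives > 80 ug/mL, which is a limit of the assay rather than a measured number. A related compound, compound 1 (`COC(=O)c1cc(-c2cccc(NC(=O)c3ccc(/C=C/C(=O)c4cccs4)cc3)c2)on1`), carries in this assay only the entry "not determined" (no result reported), so no result is available for it. Of the two entries shown, compound 2 therefore sits at the limit of > 80 ug/mL in this assay, at which 1 of the 2 values shown sits, and no measured step between two compounds can be drawn from this pair.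

Compound 3 (`COC(=O)c1cc(-c2cccc(NC(=O)c3ccc(/C=C/C(=O)c4ccc([N+](=O)[O-])cc4)cc3)c2)on1`) has not yet been measured. It differs from compound 2 in a single place: 4-nitrophenyl in place of 4-methyl-3-nitrophenyl on a carbonyl carbon. For the measured compounds named here, with no measured step available as a guide, the step that the limit leaves unreadable from compound 2 to compound 3 is expected to be none beyond the usual scatter. Compound 3 is accordingly estimated at 100 ug/mL in this assay, with a range from 40 ug/mL to 300 ug/mL, and the most likely outcome is that the assay again reports only a limit rather than a number.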

Compound 3, half-maximal cytotoxic concentration: > 20 ug/mL
Compound 3: no number, only a limit; the forecaster's own chance of this, stated with the estimate: 70%; the middle value is on the limit's open side.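

In this assay compound 2 gives > 80 ug/mL, which is a limit and not a number. Compound 3 gives > 20 ug/mL, which is also a limit. The step between compound 2 and compound 3 therefore cannot be read. The compounds shown leave open whether 4-nitrophenyl in place of 4-methyl-3-nitrophenyl changes the cytotoxic concentration at all.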